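The compounds below may be only part of what the source reports. "The series", "measured", "known", "first", "only" and "open" are said of these compounds alone.

The measured compounds:
Compound 1 `COC(=O)c1cc(=O)c2cc(NC(=O)Nc3ccc(Cl)c(C(F)(F)F)c3)ccc2[nH]1` — in a functional assay on UoC-B1 cells (Homo sapiens) for antiproliferative activity, with a stated time of 72 h (on this read-out lower numbers stand for an effect already at smaller amounts and higher numbers for an effect only at larger amounts of compound), compound 1 reaches only the limit > 6350 nM.
Compound 2 `COC(=O)c1cc(=O)c2cc(NC(=O)Nc3ccc(Cl)c(Cl)c3)ccc2[nH]1` — in this assay compound 2 also stands at the limit > 6350 nM.
Compound 3 `COC(=O)c1cc(=O)c2cc(NC(=O)Nc3ccc4c(c3)OCCO4)ccc2[nH]1` — in this assay compound 3 stands at the limit > 13200 nM.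

Compound 2 therefore stands at a limit, and the two further values shown are limits as well: the limit of > 6350 nM in this assay, at which 2 of the 3 values shown sit, and (the limit of > 13200 nM in this assay, at which 1 of the 3 values shown sits). Among the measured compounds shown here, the one single-place comparison among the measured compounds, a step that the two limits leave unreadable from compound 1 to compound 2, cannot be read because both of its ends sit at the limit of > 6350 nM in this assay, at which 2 of the 3 values shown sit.

Compound 4 `COC(=O)c1cc(=O)c2cc(NC(=O)Nc3ccc4c(c3)CCC4)ccc2[nH]1` differs from compound 2 in one place: 2,3-dihydro-1H-inden-5-yl in place of 3,4-dichlorophenyl on an amide-type nitrogen. For the measured compounds named here, no measured step bears directly on this change, and the step from compound 1 to compound 2 gives no readable size. The three measured compounds show nothing but limits in this assay, and nothing among them points to a number appearing for compound 4. The expectation for the step from compound 2 to compound 4 in this assay is therefore none readable beyond the scatter, a step that the limit leaves unreadable from compound 2 to compound 4, with a limit the likely outcome. For compound 4 in this assay the estimate is 10000 nM, expected to lie between 3000 nM and 30000 nM.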

Compound 4, half-maximal effective concentration: > 24100 nM
Compound 4 ended at the assay's limit (the forecaster's own chance of this, stated with the estimate: 75%); middle value at least 2.4-fold (0.38 log units) from the limit.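

In this assay compound 4 gives only a limit, > 24100 nM, and not a number. Compound 2 also stands at a limit, so no step can be read between compound 2 and compound 4. The compounds shown leave open whether any group on the amide-type nitrogen changes the antiproliferative read-out at all.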